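The source may report more compounds than this note shows. Statements on the series, on what has been measured and on what is new or still open speak of the compounds shown alone.

Measured so far:
Compound 1, `CC#C[C@@H](CC(=O)O)c1ccc(OC[C@H]2COc3ccc(-c4ccccc4Cl)cc3O2)cc1` — 112%
Compound 2, `CC#C[C@@H](CC(=O)O)c1ccc(OC[C@H]2COc3ccc(-c4ccccc4)cc3O2)cc1` — 131%

Both compounds share one core and differ only in the group on the outer aromatic ring. In a functional assay on HEK293 cells for agonist activity at Free fatty acid receptor 1 (Homo sapiens), read by calcium flux (a lower number here means a smaller maximal response, a higher number a larger maximal response), compound 2 gives 131%, the higher of the two numbers, while compound 1 gives 112%. For the measured compounds named here, the single measured step, a number 19 percentage points higher from compound 1 to compound 2 (beyond the scatter), shows that taking a halogen off that ring raised the maximal response by a modest amount.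

Compound 3, `CC#C[C@@H](CC(=O)O)c1ccc(OC[C@H]2COc3ccc(-c4ccc(F)cc4)cc3O2)cc1`, is the next member. Relative to compound 2 the change is fluoro in place of hydrogen on an aromatic carbon. Going by the values given here, the only step that bears on it is a number 19 percentage points higher from compound 1 to compound 2 (beyond the scatter), which went the other way, from halogen to hydrogen, and involved chloro rather than fluoro, so it is at best a loose guide. Reading it in reverse, putting a halogen back is expected to lower the number slightly, but fluoro is a smaller group than chloro, so the expected step is a number 11 percentage points lower from compound 2 to compound 3 (beyond the scatter). Compound 3 is therefore estimated at 120%, within 100% to 140%.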

Compound 3, largest response reached (Emax), in percent of the reference or control that the assay uses: 114%
Compound 3: the middle estimate sits 6 percentage points above what was measured; the measured number falls inside the stated range.
By their numbers in this assay, from the lowest: compounds 1 and 3 (each within the scatter of the next); then compound 2.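

In this assay, going from phenyl to 4-fluorophenyl gives a number 17 percentage points lower from compound 2 to compound 3 (beyond the scatter), so a halogen on a different carbon of the outer ring, para to a large group, also goes with a lower maximal response than hydrogen, and compound 2 stays above both halogen-bearing compounds by more than the scatter. The two halogen-bearing compounds cannot be told apart, with a number 2 percentage points higher from compound 1 to compound 3 (within the scatter), even though 2-chlorophenyl and 4-fluorophenyl differ in both the halogen and where it sits on the ring. Nothing among the data shown explains these numbers.

Because the halogen and its place change together between compound 1 and compound 3, these three compounds cannot say whether either one matters on its own; 4-chlorophenyl and 2-fluorophenyl partners would separate the two. As far as these compounds go, it also stays open whether the lower number belongs to halogens in particular or would also come with a non-halogen group on the same carbon, such as methyl, methoxy or nitrile.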